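Carbonyl substituent swap from compound 3 to compound 4

A few compounds are considered here, and "the series" means these few. Any claim that something is new, unique, unknown or untested is made for them only; others in the source may bear on it.

Measured so far in a physicochemical assay for solubility, read by HPLC, with a stated time of 24 h; a higher number here means a more soluble compound, a lower number a less soluble compound
compound 1 `CC(C)(C)c1[nH]cnc1/C=c1\[nH]c(=O)/c(=C/c2cccc(C(=O)c3ccccc3)c2)[nH]c1=O` gives < 0.1 ug/mL (a limit of the assay)
compound 2 `CC(C)(C)c1[nH]cnc1/C=c1\[nH]c(=O)/c(=C/c2cccc(C(=O)N3CCCC3)c2)[nH]c1=O` gives 0.454 ug/mL
compound 3 `CC(C)(C)c1[nH]cnc1/C=c1\[nH]c(=O)/c(=C/c2cccc(C(=O)c3cccs3)c2)[nH]c1=O` gives < 0.1 ug/mL (a limit of the assay)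

Compound 3 gives < 0.1 ug/mL as a limit and not a number. Its place on the scale is therefore unreadable, and it shares that limit with another compound (the limit of < 0.1 ug/mL in this assay, at which 2 of the 3 values shown sit). Only compound 2 carries a number (0.454 ug/mL).

Compound 4 `CC(C)(C)c1[nH]cnc1/C=c1\[nH]c(=O)/c(=C/c2cccc(C(=O)c3ccoc3)c2)[nH]c1=O` has furan-3-yl in place of thiophen-2-yl on a carbonyl carbon. The two readable steps (an at least 4.5-fold higher number from compound 1 to compound 2 (0.65 log units; beyond the scatter) and an at least 4.5-fold lower number from compound 2 to compound 3 (0.65 log units; beyond the scatter)) are each sized against a limit. Both turn on pyrrolidin-1-yl, which compound 4 does not carry, so they say little here. The nearest guide is thiophen-2-yl in place of phenyl on a carbonyl carbon (a step that the two limits leave unreadable from compound 1 to compound 3). That step leaves compound 1 and compound 3 at the same limit, so no step beyond the scatter is expected in this assay and no direction can be named. Compound 4 is expected to stay near the limit and may also be reported only as one. The estimate amounts to an expected step (a number no lower from compound 3 to compound 4 (the limit leaves the size open)). The estimate for compound 4 is 0.1 ug/mL (expected range 0.03 ug/mL to 0.35 ug/mL).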

Compound 4, solubility: < 0.1 ug/mL
Compound 4 was reported as a limit; the forecaster's own chance of this, stated with the estimate: 60%; the middle value lies on the limit itself.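

In this assay compound 4 gives < 0.1 ug/mL, which is a limit of the assay and not a number. With furan-3-yl in place of pyrrolidin-1-yl on a carbonyl carbon there is an at least 4.5-fold lower number from compound 2 to compound 4 (0.65 log units; beyond the scatter), so a third five- or six-membered aromatic group on the carbonyl carbon joins phenyl in compound 1 and thiophen-2-yl in compound 3, and among the compounds shown only compound 2, with pyrrolidin-1-yl, reads as a number, with no compound going against that. The steps among compound 1, compound 3 and compound 4 cannot be read, and oxygen in place of sulfur as the ring hetero atom, with furan-3-yl for thiophen-2-yl, therefore has no readable size, since all three compounds sit at one limit: the limit of < 0.1 ug/mL in this assay, at which 3 of the 4 values shown sit.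

As far as these compounds go, how far compound 1, compound 3 and compound 4 lie from that limit, and whether they differ at all, stays open. Also open, from the compounds shown here alone, is whether morpholin-4-yl or dimethylamino on the carbonyl carbon would give a readable number too, and so whether the reading of compound 2 belongs to pyrrolidin-1-yl alone.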